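From Trifluoromethoxy to Methylsulfanyl: What to Expect

The compounds below may be only part of what the source reports. "The series", "measured", "known", "first", "only" and "open" are said of these compounds alone.

Compound 1 `COc1ccccc1-c1ncnn1-c1cc(OC)c(OC)c(OC)c1`: in a functional assay on Jurkat cells (Homo sapiens) for antiproliferative activity, read by MTT assay, with a stated time of 72 h (a higher number here means a weaker inhibitor, a lower number a stronger inhibitor), compound 1 gives > 10000 nM, a limit of the assay.
Compound 2 `CCOc1ccc(-c2ncnn2-c2cc(OC)c(OC)c(OC)c2)cc1`: in this assay compound 2 gives 5 nM.
Compound 3 `COc1cc(-n2ncnc2-c2ccc(OC(F)(F)F)cc2)cc(OC)c1OC`: in this assay compound 3 gives > 10000 nM, again a limit.

Compound 3 therefore stands at the limit where two of the three values sit (the limit of > 10000 nM in this assay, at which 2 of the 3 values shown sit). Compound 4 `COc1cc(-n2ncnc2-c2ccc(SC)cc2)cc(OC)c1OC` differs from it in one place: methylsulfanyl in place of trifluoromethoxy on an aromatic carbon. Going by the values given here, one measured step bears on this change: an at least 2000-fold higher number from compound 2 to compound 3 (3.30 log units; beyond the scatter), ending at the limit. Methylsulfanyl is neither ethyl nor trifluoromethyl on an oxygen, so that step only shows that this place can swing potency strongly. Since compound 2, with ethyl on the oxygen, gives 5 nM, some recovery seems plausible, though uncertain. Compound 4 is expected to give 500 nM (range 20 nM to 10000 nM), an estimated step of an at least 20-fold lower number from compound 3 to compound 4 (1.30 log units; beyond the scatter).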

Compound 4, half-maximal inhibitory concentration: 50 nM
Compound 4: middle estimate off by 10-fold (1.00 log units), on the high side, and the stated range covers the measured number.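

Compound 1 and compound 3 each stand at a limit of the assay, not at a number, so the steps from them are limits too: the limit of > 10000 nM in this assay, at which 2 of the 4 values shown sit.

In this assay, methylsulfanyl restores strong potency, with an at least 200-fold lower number from compound 3 to compound 4 (2.30 log units; beyond the scatter) and an at least 200-fold lower number from compound 1 to compound 4 (2.30 log units; beyond the scatter), so the group on this aromatic carbon need not be joined through oxygen. Ethoxy still stays ahead, with a 10-fold higher number from compound 2 to compound 4 (1.00 log units; beyond the scatter).

Going by these compounds, what remains open is how an amine, a hydroxyl or a longer sulfur-linked chain such as ethylsulfanyl would fare at this place. Whether any of them could match ethoxy cannot be told from these compounds.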